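The compounds below may be only part of what the source reports. "The series", "measured", "known", "first", "only" and "open" are said of these compounds alone.

Series notes. Two sulfonamides carry numbers in a functional assay on BXPC-3 cells (Homo sapiens) for inhibition, read by MTT assay, with a stated time of 72 h; on this read-out lower numbers stand for stronger inhibition of growth and higher numbers for weaker inhibition of growth. Compound 1 `O=S(=O)(NCCCCNCc1ccc(Br)cc1)c1cc(C(F)(F)F)cc(C(F)(F)F)c1` gives 1700 nM. Compound 2 `COc1ccc(CNCCCNS(=O)(=O)c2cc(C(F)(F)F)cc(C(F)(F)F)c2)cc1OC` gives 13000 nM, the higher of the two numbers, with compound 1 lying lower by a gap beyond the scatter. Compound 3 `O=S(=O)(NCCCNCc1ccccc1)c1cc(C(F)(F)F)cc(C(F)(F)F)c1` is not yet measured; it differs from compound 2 by phenyl in place of 3,4-dimethoxyphenyl on a saturated chain carbon bound to an amine nitrogen. Within the data shown here, no measured pair shows this change, so its effect is open; a step toward a lower number of modest size is expected, and one within the scatter would not surprise. Compound 3 is expected to give 7000 nM, with a range from 2500 nM to 20000 nM. The step this estimate means, a 1.9-fold lower number from compound 2 to compound 3 (0.27 log units; within the scatter), is expected in this assay.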

Compound 3, concentration for 50% growth inhibition: 13000 nM
Compound 3: middle estimate off by 1.9-fold (0.27 log units), on the low side, and the stated range covers the measured number.
By their numbers in this assay, from the lowest: compound 1; then compounds 2 and 3 (each within the scatter of the next).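

In this assay, phenyl in place of 3,4-dimethoxyphenyl on a saturated chain carbon bound to an amine nitrogen gives no change at the digits printed from compound 2 to compound 3 (within the scatter), so the two groups are not told apart at this position. Benzylamino in place of ((4-bromobenzyl)amino)methyl gives a 7.6-fold higher number from compound 1 to compound 3 (0.88 log units; beyond the scatter), but this single step joins the loss of bromine with a change in chain, and neither can be credited alone. No measurement here accounts for either result.

Still open, going by these compounds, is whether the 4-bromobenzyl group or the longer chain carries this gap. A 4-chlorobenzyl group at the same place is also untested in the compounds shown.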